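Bromine for Chlorine, Carried From One Core to Another

A few compounds are considered here, and "the series" means these few. Any claim that something is new, unique, unknown or untested is made for them only; others in the source may bear on it.

Compound 1, `Cn1c(=O)c2c(nc([S+]([O-])CCc3ccc(Cl)cc3)n2C)n(C)c1=O`: 781 nM
Compound 2, `Cn1c(=O)c2c(nc([S+]([O-])CCc3ccc(Br)cc3)n2C)n(C)c1=O`: 471 nM
Compound 3, `Cn1c(=O)c2c(nc(SCc3cccc(Cl)c3)n2C)n(C)c1=O`: 227 nM

All three were measured in an assay on microsomes for inhibition of Amine oxidase [flavin-containing] B (Homo sapiens), read by fluorescence and spectrophotometry, with a stated time of 20 min; on this read-out lower numbers stand for stronger inhibition and higher numbers for weaker inhibition. Compound 1 and compound 2 differ by bromo in place of chloro on an aromatic carbon, and that step gave a 1.7-fold lower number from compound 1 to compound 2 (0.22 log units; within the scatter). Compound 3 gives the lowest number of the three, beyond the scatter of both others; the difference between its core and the core of compound 1 is not broken down here. Compound 4, `Cn1c(=O)c2c(nc(SCc3cccc(Br)c3)n2C)n(C)c1=O`, has not been measured. It differs from compound 3 by bromo in place of chloro on an aromatic carbon. For the measured compounds named here, this is the same kind of change as the one from compound 1 to compound 2, not the same: there the bromo stands para to a large group, here meta to a large group. Resting on the earlier step, the step from compound 3 to compound 4 is expected to be a 1.5-fold lower number from compound 3 to compound 4 (0.18 log units; within the scatter). Compound 4 is estimated at 150 nM, between 70 nM and 350 nM.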

Compound 4, half-maximal inhibitory concentration: 199 nM
For compound 4 the middle estimate is 1.3-fold (0.12 log units) below the measured one, within the range that was stated.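

In this assay, bromo in place of chloro on the core of compound 3 gave a 1.1-fold lower number from compound 3 to compound 4 (0.06 log units; within the scatter). Set beside the earlier step, the change carried from one core to the other without a difference that can be told apart: the same change on two cores in this assay, a 1.7-fold lower number (0.22 log units; within the scatter) from compound 1 to compound 2 and a 1.1-fold lower number (0.06 log units; within the scatter) from compound 3 to compound 4, 1.5-fold (0.16 log units) apart, within the scatter of two such steps. For the compounds shown here, both steps lie within the scatter, so the pair does not show that bromo improves on chloro, and with only two cores, which also differ in where the halogen stands, it cannot separate the effect of the core from that of the position.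

The compounds shown leave open how a fluoro, a methoxy or an amine would fare at the same place. They also leave open whether the step would hold on a third core.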